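Extending the open-chain amine on the shared core

This account rests on a few compounds, and the source may have more. Where it says the series, first, only, none or still open, it means among the compounds named here.

Measured in an assay on isolated protein for inhibition of DNA topoisomerase 1 (Homo sapiens), with a stated time of 15 min; on this read-out higher numbers stand for weaker inhibition and lower numbers for stronger inhibition:
compound 1 `CN[C@@H]1CCN(c2c(F)cc3c(=O)c(C(=O)O)cn(Cc4ccc(-c5ccccc5)cc4)c3c2OC)C1` — 57700 nM
compound 2 `COc1c(N2CC[C@@H](CN)C2)c(F)cc2c(=O)c(C(=O)O)cn(Cc3ccc(-c4ccccc4)cc3)c12` — 26000 nM
compound 3 `CNCCNc1c(F)cc2c(=O)c(C(=O)O)cn(Cc3ccc(-c4ccccc4)cc3)c2c1OC` — > 200000 nM (a limit of the assay, not a number)

In this assay compound 1 gives 57700 nM and compound 2 gives 26000 nM. For compound 3 the assay reports only a limit, > 200000 nM. Both measured steps into compound 3 run the same way: an at least 3.4-fold higher number from compound 1 to compound 3 (0.53 log units; beyond the scatter) and an at least 7.6-fold higher number from compound 2 to compound 3 (0.88 log units; beyond the scatter). Compound 3 therefore stands at the weak end of the three, sitting at the limit (the limit of > 200000 nM in this assay, at which 1 of the 3 values shown sits). Between the two ring amines the change is a 2.2-fold lower number from compound 1 to compound 2 (0.35 log units; beyond the scatter).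

Compound 4 `CNCCCCNc1c(F)cc2c(=O)c(C(=O)O)cn(Cc3ccc(-c4ccccc4)cc3)c2c1OC` differs from compound 3 in one place: 2-(methylamino)ethyl in place of methylamino on a saturated chain carbon, two bonds along the chain from a nitrogen on an aromatic ring. Within the data shown here, no measured pair tests a change of chain length; the two steps into compound 3 concern exchanging a ring amine for an open chain, and both end at the limit. There is thus nothing that points to a recovery of inhibition on lengthening the chain. Compound 4 is expected to remain near the limit in this assay, estimated at 200000 nM within a range of 60000 nM to 600000 nM. The estimated step that this implies is a number no higher from compound 3 to compound 4 (the limit leaves the size open), which is expected to be nothing beyond the scatter, with a fair chance that only a limit is again reported.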

Compound 4, half-maximal inhibitory concentration: > 200000 nM
Compound 4 was reported as a limit (the forecaster's own chance of this, stated with the estimate: 60%); the middle value lies on the limit itself.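

In this assay compound 4 is reported only as a limit, > 200000 nM, so replacing methylamino with 2-(methylamino)ethyl on the saturated chain carbon does not bring the open chain into the measurable range, and the limit now holds for both chain lengths shown: the limit of > 200000 nM in this assay, at which 2 of the 4 values shown sit.

Both ring amines remain ahead of the longer chain, with an at least 3.4-fold higher number from compound 1 to compound 4 (0.53 log units; beyond the scatter) and an at least 7.6-fold higher number from compound 2 to compound 4 (0.88 log units; beyond the scatter) as the readable steps. The step between the two open chains cannot be read, as both ends are limits, so no order of compound 3 and compound 4 follows and no effect of chain length can be stated.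

On these data alone, how far either chain lies beyond the limit remains open, and with it whether lengthening changes inhibition at all. Also open, as far as these compounds go, is whether an open chain can reach the range of the ring amines at all, for instance (3-(methylamino)propyl)amino as the intermediate length, or a chain ending in a primary amine such as (2-aminoethyl)amino.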